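The compounds below may be only part of what the source reports. "The series", "measured", "known", "first", "only" and "open" are said of these compounds alone.

Compound 1, `COc1cc(-c2cccc3nc(-c4ccc(F)cc4)oc23)cc(OC)c1OC`, gives > 25000 nM in a functional assay on U-251 cells (Homo sapiens) for antiproliferative activity, read by MTT assay, with a stated time of 48 h (on this read-out higher numbers stand for weaker inhibition and lower numbers for stronger inhibition), which is a limit of the assay rather than a number.
Compound 2, `COc1cc(-c2cccc3nc(-c4ccc(Cl)cc4)oc23)cc(OC)c1OC`, gives 1600 nM in this assay.
Compound 3, `COc1cc(-c2cccc3nc(-c4cccc(O)c4)oc23)cc(OC)c1OC`, gives 5500 nM in this assay.

Of the two numbers on hand, compound 2 has the lowest; its nearest neighbour is compound 3, with a 3.4-fold higher number from compound 2 to compound 3 (0.54 log units; beyond the scatter). Compound 1 sits only at the limit of > 25000 nM in this assay, at which 1 of the 3 values shown sits. Compound 4, `COc1cc(-c2cccc3nc(-c4cccs4)oc23)cc(OC)c1OC`, has not yet been measured in this assay. It differs from compound 2 in one place: thiophen-2-yl in place of 4-chlorophenyl on an aromatic carbon. Every measured step in this series changes the same group on the shared core. Replacing fluoro by chloro gave an at least 15-fold lower number from compound 1 to compound 2 (1.19 log units; beyond the scatter), a large shift; moving from 4-fluorophenyl to 3-hydroxyphenyl gave an at least 4.5-fold lower number from compound 1 to compound 3 (0.65 log units; beyond the scatter); and going from 4-chlorophenyl to 3-hydroxyphenyl gave a 3.4-fold higher number from compound 2 to compound 3 (0.54 log units; beyond the scatter). None of these steps involves thiophen-2-yl, so they show only that this position can move the number by modest to large amounts, and that compound 2 is the lowest point reached so far. A modest step upward from compound 2 is therefore expected for compound 4, estimated as a 2.2-fold higher number from compound 2 to compound 4 (0.34 log units; beyond the scatter). Compound 4 is estimated at 3500 nM in this assay, with a range from 900 nM to 14000 nM.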

Compound 4, half-maximal inhibitory concentration: 3000 nM
The estimate for compound 4 lay 1.2-fold (0.07 log units) above the measured number; the measured number falls inside the stated range.
By their numbers in this assay, from the lowest: compounds 2, 4 and 3 (each within the scatter of the next, the first and the last beyond it). At a limit, above all of these: compound 1.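

Thiophen-2-yl, a five-membered aromatic ring with one hetero atom, can take the place of a six-membered aromatic ring here without a clear change in this assay: a 1.9-fold higher number from compound 2 to compound 4 (0.27 log units; within the scatter) and a 1.8-fold lower number from compound 3 to compound 4 (0.26 log units; within the scatter) both lie within the scatter. This position is therefore not tied to 4-chlorophenyl or 3-hydroxyphenyl, and a smaller ring carrying no substituent gives a number that cannot be told apart from either of theirs, while the change from the group in compound 1 gives an at least 8.3-fold lower number from compound 1 to compound 4 (0.92 log units; beyond the scatter), so among the four groups shown, 4-fluorophenyl alone stands apart from the other three. The value of compound 1 is a limit and not a number, so this last step has only a minimum size: the limit of > 25000 nM in this assay, at which 1 of the 4 values shown sits.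

The compounds shown leave open how a plain phenyl or a 4-bromophenyl group would compare, which would help to show whether the wide gap between the fluoro and chloro compounds extends to other halogens. They also leave open what furan-2-yl, a pyridyl ring, or a phenyl ring bearing an amine or a carboxylic acid would give at this position.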